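The source may report more compounds than this note shows. Statements on the series, on what has been measured and on what is new or still open speak of the compounds shown alone.

Measured so far:
compound 1, `CCCCCCCCCCCCCCCCCCc1c(O)cc(O)c(C(C)=O)c1O` — 26000 nM
compound 2, `CCCCCCCC/C=C\CCCCCCCCOc1cc(O)cc(O)c1C(C)=O` — > 100000 nM
compound 3, `CCCCCCCCCCCCCCCCCCOc1cc(O)cc(O)c1C(C)=O` — > 100000 nM

In a functional assay on HeLa cells (Homo sapiens) for cytotoxicity, read by XTT assay, with a stated time of 72 h (on this read-out higher numbers stand for weaker inhibition and lower numbers for stronger inhibition), compound 1 gives 26000 nM. Compound 3 gives only a limit of the assay, > 100000 nM. Compound 2 likewise gives only a limit, > 100000 nM. Compound 1 and compound 3 share the same atoms joined differently; the difference between the two cores is not broken down here. Compound 3 and compound 2 differ by dec-1-en-1-yl in place of decyl on a saturated chain carbon, eight bonds along the chain from an oxygen on an aromatic ring, and that step, a step that the two limits leave unreadable from compound 3 to compound 2, cannot be read because of the limit of > 100000 nM in this assay, at which 2 of the 3 values shown sit.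

Compound 4, `CCCCCCCC/C=C\CCCCCCCCc1c(O)cc(O)c(C(C)=O)c1O`, is not yet measured. It differs from compound 1 by dec-1-en-1-yl in place of decyl on a saturated chain carbon, eight bonds along the chain from an aromatic carbon. This is the same kind of change as from compound 3 to compound 2, though here it sits eight bonds along the chain from an aromatic carbon rather than from an oxygen on an aromatic ring. Going by the values given here, since the earlier step of the same kind is unreadable, the expectation rests mainly on compound 1, whose value 26000 nM is the only number available. Compound 4 is therefore expected to stay near that, with an estimated step of a 1.3-fold lower number from compound 1 to compound 4 (0.11 log units; within the scatter) in this assay. The estimate for compound 4 is 20000 nM, between 7000 nM and 60000 nM.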

Compound 4, half-maximal inhibitory concentration: > 100000 nM
Compound 4: a limit, no number; the forecaster's own chance of this, stated with the estimate: 10%; middle value at least 5.0-fold (0.69 log units) away from the limit.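

On the core of compound 1, putting dec-1-en-1-yl in place of decyl brings an at least 3.8-fold higher number from compound 1 to compound 4 (0.58 log units; beyond the scatter) in this assay, so this single change weakens the read-out on this core. Compound 4 gives > 100000 nM, which is a limit of the assay and not a number, and the full size of the step is not known. The same change on the core of compound 3 cannot be read, so these compounds do not show whether the effect carries from one core to the other, because so many values sit at the same limit: the limit of > 100000 nM in this assay, at which 3 of the 4 values shown sit.

Going by these compounds alone, compound 1 is the only compound here with a measured number, 26000 nM, so a single value anchors every comparison. On these data alone, whether a shorter saturated chain, or a chain ending in an amine or a carboxylic acid, would give a readable value on either core stays open.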